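This account rests on a few compounds, and the source may have more. Where it says the series, first, only, none or still open, it means among the compounds named here.

Working notes on the series. In a functional assay on U-87MG ATCC cells for antiproliferative activity against U-87 MG (Homo sapiens), with a stated time of 5 days (a lower number here means that less compound is needed, a higher number that more compound is needed for the effect), compound 2 (`CCOC(Cn1nc(-c2ccc3oc(N)nc3c2)c2c(N)ncnc21)OCC`) gives 100 nM. Compound 1 (`Nc1nc2cc(-c3nn(C[C@H]4CCCO4)c4ncnc(N)c34)ccc2o1`) gives 100 nM and compound 3 (`Nc1nc2cc(-c3nn(C[C@@H]4CCCO4)c4ncnc(N)c34)ccc2o1`) gives 100 nM, so compound 2 stands level with both. Compound 4 (`COC(Cn1nc(-c2ccc3oc(N)nc3c2)c2c(N)ncnc21)OC`) has not yet been measured in this assay. Its difference from compound 2 is dimethoxymethyl in place of diethoxymethyl on a saturated chain carbon bound to an aromatic nitrogen. Cut one bond further out, the same difference reads 2,2-diethoxyethyl to 2,2-dimethoxyethyl.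

Going by the values given here, no measured step makes this exact exchange, so the evidence is indirect. The closest steps exchange oxolan-2-yl and diethoxymethyl at the same place: no change at the digits printed from compound 1 to compound 2 (within the scatter), and no change at the digits printed from compound 2 to compound 3 (within the scatter). Both lie within the scatter. The remaining step, no change at the digits printed from compound 1 to compound 3 (within the scatter), comes with the fact that compounds 1 and 3 differ only in the configuration as drawn and also lies within the scatter, though it does not touch the diethoxymethyl group. All three compounds therefore sit level at this place, and no direction can be drawn from them. In this assay, no change beyond the scatter is expected. The expected step is no change at the digits printed from compound 2 to compound 4 (within the scatter). For compound 4 the estimated value is 100 nM, with an expected range of 45 nM to 220 nM.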

Compound 4, half-maximal effective concentration: 100 nM
Beside the measured number, compound 4's estimate shows no gap at the digits printed, and the stated range covers the measured number.
By their numbers in this assay, from the lowest: compounds 1, 2, 3 and 4 (each within the scatter of the next).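

The direct exchange is now on record: in this assay, going from diethoxymethyl, with 7 heavy atoms, to dimethoxymethyl, with 5, on a saturated chain carbon bound to an aromatic nitrogen gives no change at the digits printed from compound 2 to compound 4 (within the scatter). The earlier compounds shown here compared diethoxymethyl only with the oxolan-2-yl group, whereas this result adds a smaller open-chain group at the same place and leaves the read-out level. The exchange of oxolan-2-yl for dimethoxymethyl also reads alike from both ring compounds, no change at the digits printed from compound 3 to compound 4 (within the scatter) and no change at the digits printed from compound 1 to compound 4 (within the scatter), so the level result holds whichever configuration is drawn at the ring carbon, and the two starting points are otherwise identical: the fact that compounds 1 and 3 differ only in the configuration as drawn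

Among these four compounds, the three groups at this place cannot be told apart in this assay, but all of them carry two oxygen atoms and no charge, so the level reading extends no further than these groups. From the compounds shown here alone, whether a plain ethyl chain, an amine, a carboxylic acid or a longer chain such as dipropoxymethyl at the same place would stay level remains open, as does any change to the shared core.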